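The source may report more compounds than this note shows. Statements on the series, on what has been measured and on what is new or still open speak of the compounds shown alone.

Notes on the series. In a functional assay on MDA-MB-231 cells (Homo sapiens) for antiproliferative activity, read by MTT assay, with a stated time of 48 h (a higher number here means a weaker inhibitor, a lower number a stronger inhibitor), compound 1 `CCOC(=O)CNc1nc(Nc2cccc(OC)c2)ncc1[N+](=O)[O-]` gives 31300 nM. Compound 2 `CCOC(=O)CN(Cc1ccccc1)c1nc(Nc2ccccc2)ncc1[N+](=O)[O-]` returns only a limit here, > 100000 nM, so compound 2 stands at the limit of > 100000 nM in this assay, at which 1 of the 2 values shown sits, and no number is known for it. Compound 3 `CCOC(=O)CN(Cc1ccccc1)c1nc(Nc2cccc(OC)c2)ncc1[N+](=O)[O-]` differs from compound 2 by methoxy in place of hydrogen on an aromatic carbon. Going by the values given here, no step between two measured compounds differing in one place is available, so the change from compound 2 to compound 3 is expected to be small, an at least 1.1-fold lower number from compound 2 to compound 3 (0.04 log units; that floor lies within the scatter), with a real chance that this assay again records only a limit. Compound 3 is estimated at 90000 nM, range 30000 nM to 200000 nM.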

Compound 3, half-maximal inhibitory concentration: 47200 nM
Compound 3: middle estimate off by 1.9-fold (0.28 log units), on the high side; the range from low to high includes it.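

Methoxy in place of hydrogen on the aromatic carbon, the change from phenyl to 3-methoxyphenyl, gives a measured number in this assay, with an at least 2.1-fold lower number from compound 2 to compound 3 (0.32 log units; beyond the scatter). From the compounds shown here alone, compound 2 has only a limit, so this step is a floor and its full size stays unknown: the limit of > 100000 nM in this assay, at which 1 of the 3 values shown sits. With the 3-methoxyphenyl group in place, benzyl in place of hydrogen on the nitrogen gives a 1.5-fold higher number from compound 1 to compound 3 (0.18 log units; within the scatter), so that change is not separable from the scatter.

Open remains whether hydroxy in place of methoxy keeps the number, and whether a longer chain or an amine in place of benzyl on the nitrogen does.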